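The source may hold more compounds than are shown below. What is called first, only, known or untested is meant among the compounds shown, and "the series" means these compounds.

Compound 2, with the structure `COc1ccc(Cc2nc(-c3cc(Br)c(O)c(Br)c3)c[nH]c2=O)cc1Br`, is the starting point of this step, and in a functional assay on MCF7 cells (Homo sapiens) for inhibition, read by MTT assay, with a stated time of 24 h (a lower number here means a stronger inhibitor, a higher number a weaker inhibitor), compound 2 has no single number: "not determined" (no result reported), no result was reported for it. Compound 3, with the structure `COc1ccc(Cc2nc(-c3cc(Br)c(O)c(Br)c3)cnc2Cl)cc1Br`, likewise has no result reported in this assay: compound 3 stands at "not determined" (no result reported). Among the measured compounds shown here, the only compound in the set with a measured value is compound 1, with the structure `CNCCCOc1c(Br)cc(-c2c[nH]c(=O)c(Cc3ccc(OC)c(Br)c3)n2)cc1Br`; in this assay compound 1 gives 10900 nM, a weak inhibition.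

Compound 4, with the structure `COc1ccc(Cc2nc(-c3cc(Br)c(OCCCN(C)C)c(Br)c3)c[nH]c2=O)cc1Br`, is the compound yet to be measured. It differs from compound 2 in one place: 3-(dimethylamino)propyl in place of hydrogen on an oxygen on an aromatic ring. Put another way, the hydroxy group of compound 2 becomes a 3-(dimethylamino)propoxy group in compound 4.

For the measured compounds named here, since compound 2 has no number, the size and direction of this step cannot be read from the data; no step between any two measured compounds is given, so there is nothing in the set to say whether such a change helps, hurts, or does nothing beyond the scatter. Going by the values given here, the expectation for compound 4 therefore rests on a single reference point, the one value in the set.

Compound 4 is expected to sit near 10000 nM, with a likely range from 3000 nM to 40000 nM, because compound 1 gives 10900 nM in this assay.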

Compound 4, half-maximal inhibitory concentration: 6900 nM
Estimate against measurement, compound 4: 1.4-fold (0.16 log units) above, and the stated range covers the measured number.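

In this assay, placing a methyl in place of hydrogen on the amine nitrogen of the side chain gives a 1.6-fold lower number from compound 1 to compound 4 (0.20 log units; within the scatter). Among the compounds shown here, this is the first readable comparison in the set, and it shows that compound 1 and compound 4, which carry one and two methyl groups on that nitrogen, cannot be told apart in this assay. No measurement shown here offers an explanation for this result.

On these data alone, compound 2 and compound 3 have no reported result, so every step involving them cannot be read, and the effect of replacing the hydroxy group with 3-(dimethylamino)propoxy on the aromatic ring remains unknown. The compounds shown also leave open how this assay would respond to a primary amine at the end of the chain, to a nitrogen held within a morpholine ring, to a carboxylic acid in place of the amine, or to a longer chain between the oxygen and the nitrogen.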